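Dropping the Methoxy Group of an Inactive Sulfonylated Compound

The source may report more compounds than this note shows. Statements on the series, on what has been measured and on what is new or still open speak of the compounds shown alone.

Measured compounds in a functional assay on A549 cells (Homo sapiens) for cytotoxicity; on this read-out higher numbers stand for weaker inhibition and lower numbers for stronger inhibition:
compound 1 `COc1ccc2c(c1)c(-c1cc(C(F)(F)F)c(C#N)c(-c3cn(S(=O)(=O)c4ccc(C)cc4)c4ccc(OC)cc34)n1)cn2S(=O)(=O)c1ccc(C)cc1`: > 100000 nM
compound 2 `COc1ccc2c(-c3cc(C(F)(F)F)c(C#N)c(-c4cn(S(=O)(=O)c5ccc(C)cc5)c5cc(OC)ccc45)n3)cn(S(=O)(=O)c3ccc(C)cc3)c2c1`: > 100000 nM
compound 3 `COc1ccc2c(c1)c(-c1cc(C(F)(F)F)ccn1)cn2S(=O)(=O)c1ccc(C)cc1`: > 100000 nM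

In this assay compound 1 gives > 100000 nM, which is a limit of the assay and not a number. Compound 2 likewise gives > 100000 nM, again a limit. Compound 3 gives > 100000 nM, also a limit. Among the compounds with values here, compound 3 therefore stands nowhere in particular among the three: every value shown is the limit of > 100000 nM in this assay, at which 3 of the 3 values shown sit, and no step between measured compounds can be given a size or a direction.

Compound 4 `Cc1ccc(S(=O)(=O)n2cc(-c3cc(C(F)(F)F)ccn3)c3ccccc32)cc1` differs from compound 3 by hydrogen in place of methoxy on an aromatic carbon of a six-membered aromatic ring of carbon only, part of a fused system of two rings. Within the data shown here, no measured step shows how such a change moves the read-out in this assay. With compound 3 sitting at the limit, the expected step is a number no higher from compound 3 to compound 4 (the limit leaves the size open), which is to say none beyond the scatter. Compound 4 is therefore estimated at 100000 nM, within a range from 30000 nM to 300000 nM, and it is expected that the assay will once more report only a limit rather than a number.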

Compound 4, half-maximal inhibitory concentration: 25000 nM
Compound 4: the middle estimate sits 4.0-fold (0.60 log units) above what was measured; measured number below the stated range.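

In this assay compound 3 gives > 100000 nM, which is a limit of the assay and not a number. Replacing the methoxy with hydrogen on this aromatic carbon, meta to a fused ring and para to a fused ring, gives an at least 4.0-fold lower number from compound 3 to compound 4 (0.60 log units; beyond the scatter), so this position is one at which a single change moves the read-out, and compound 4 is the only compound shown that returns a number rather than a limit. The step has a lower bound on its size but no exact size, and no other step in the series can be read, because most of the values are limits: the limit of > 100000 nM in this assay, at which 3 of the 4 values shown sit.

The compounds shown leave open whether the gain comes from losing the methoxy alone or whether another group on the same carbon, such as a hydroxyl, a fluorine or an amine, would give a similar or a larger change. They also leave open whether removing the methoxy groups from the larger compounds 1 and 2, whose cores also carry a nitrile and a second sulfonylated unit, would move the read-out in the same direction.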